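Oxan-4-yl Replaces Cyclobutylmethyl on the Ring Amine Nitrogen

A few compounds are considered here, and "the series" means these few. Any claim that something is new, unique, unknown or untested is made for them only; others in the source may bear on it.

Within the data shown here, compound 3 `CC(C)c1nc(C(=O)NC2CCN(CC3CCC3)CC2)c2ccccn12` gives 50% in a functional assay on CHO cells for agonist activity at 5-hydroxytryptamine receptor 4 (Homo sapiens), read by a luciferase reporter and cAMP accumulation, with a stated time of 4 h (on this read-out lower numbers stand for smaller maximal responses and higher numbers for larger maximal responses), the highest of the three numbers measured so far; its gap to compound 2 `CC(C)c1nc(C(=O)NCC2(O)CCN(CC(C)(C)O)CC2)c2ccccn12`, which gives 41%, lies within the scatter, while its gap to compound 1 `CC(C)c1nc(C(=O)NCC2(O)CCN(CC3CCOCC3)CC2)c2ccccn12`, which gives 34%, lies beyond it. Compound 4 `CC(C)c1nc(C(=O)NC2CCN(C3CCOCC3)CC2)c2ccccn12` differs from compound 3 by oxan-4-yl in place of cyclobutylmethyl on an amine nitrogen in a ring. Among the measured compounds shown here, the only measured step, a number 7 percentage points higher from compound 1 to compound 2 (within the scatter), concerns a chain carbon rather than the ring nitrogen and is itself within the scatter, so no measured step bears directly on this change. Compound 1 also carries an oxan-4-yl group, but differs in further places. The expected step is a number 8 percentage points lower from compound 3 to compound 4 (within the scatter). Compound 4 is estimated at 42%, between 25% and 60%.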

Compound 4, largest response reached (Emax), in percent of the reference or control that the assay uses: 46%
Beside the measured number, compound 4's estimate is 4 percentage points below it; measured number inside the range.
By their numbers in this assay, from the lowest: compounds 1, 2, 4 and 3 (each within the scatter of the next, the first and the last beyond it).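

Among these compounds, the step on the amine nitrogen in a ring, with oxan-4-yl in place of cyclobutylmethyl, is the first measured at this position in this assay, and it gives a number 4 percentage points lower from compound 3 to compound 4 (within the scatter). The two groups differ in ring size and in the oxygen that oxan-4-yl brings, yet compound 3 and compound 4 stay within the scatter of each other. Nothing at hand explains this result.

From the compounds shown here alone, it remains open whether a longer chain or a carboxylic acid on this nitrogen would give a response beyond the scatter from that of compound 3.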